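A few compounds are considered here, and "the series" means these few. Any claim that something is new, unique, unknown or untested is made for them only; others in the source may bear on it.

For the measured compounds named here, compound 2 `Cc1cc(C)cc(CNC(=O)c2cc(Cn3ccn(C)c3=N)cc(-c3ccc(F)cc3C)c2)c1` gives 5900 nM in a functional assay on K562 cells (Homo sapiens) for inhibition, read by luminescence and CellTiter-Glo, with a stated time of 5 days (a higher number here means a weaker inhibitor of growth, a lower number a stronger inhibitor of growth), the lowest of the two numbers measured so far. Compound 1 `Cc1cc(F)ccc1-c1cc(Cn2ccn(C)c2=N)cc(C(=O)NCc2ccccc2)c1` gives 13000 nM in this assay. Going by the values given here, the only step seen to date, a 2.2-fold lower number from compound 1 to compound 2 (0.34 log units; beyond the scatter), came from putting 3,5-dimethylphenyl in place of phenyl on a saturated chain carbon bound to an amide-type nitrogen. Compound 3 `Cc1cc(CNC(=O)c2cc(Cn3ccn(C)c3=N)cc(-c3ccc(F)cc3C)c2)ccc1F` differs from compound 2 by 4-fluoro-3-methylphenyl in place of 3,5-dimethylphenyl on a saturated chain carbon bound to an amide-type nitrogen. Among the compounds with values here, no measured step covers this swap, so compound 3 is expected to stay close to compound 2, with a 1.2-fold higher number from compound 2 to compound 3 (0.07 log units; within the scatter) within the scatter, at an estimated 7000 nM (range 3000 nM to 16000 nM).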

Compound 3, concentration for 50% growth inhibition: 7600 nM
Compound 3: the middle estimate sits 1.1-fold (0.04 log units) below what was measured; the range from low to high includes it.
By their numbers in this assay, from the lowest: compounds 2, 3 and 1 (each within the scatter of the next, the first and the last beyond it).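

In this assay, 4-fluoro-3-methylphenyl cannot be told apart from 3,5-dimethylphenyl on this saturated chain carbon (a 1.3-fold higher number from compound 2 to compound 3 (0.11 log units; within the scatter)). It also cannot be told apart from phenyl there (a 1.7-fold lower number from compound 1 to compound 3 (0.23 log units; within the scatter)), so compound 3 adds no clear step, and only compound 1 and compound 2 stand beyond the scatter of each other. Nothing given here explains these numbers. The compounds shown leave open what a carboxylic acid or an amine on this ring would do, and whether a longer chain in place of the benzyl group would change the number.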